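A few compounds are considered here, and "the series" means these few. Any claim that something is new, unique, unknown or untested is made for them only; others in the source may bear on it.

Compound 1 `CC(=O)c1c(O)ccc2oc(-c3ccccc3)nc12` reports only a limit in a functional assay on HepG2 cells (Homo sapiens) for cytotoxicity, read by MTT assay, with a stated time of 48 h (on this read-out higher numbers stand for weaker inhibition and lower numbers for stronger inhibition), > 30000 nM. Compound 2 `Cc1ccccc1-c1nc2c(C=O)c(O)ccc2o1` gives 4740 nM in this assay.

Among the measured compounds shown here, compound 2 thus holds the only numerical value shown; the remaining value is a limit (the limit of > 30000 nM in this assay, at which 1 of the 2 values shown sits). Compound 3 `CC(=O)c1c(O)ccc2oc(-c3ccccc3C)nc12` differs from compound 2 by methyl in place of hydrogen on a carbonyl carbon, a formyl-to-acetyl change. For the measured compounds named here, no measured step covers this change. Compound 1, which also carries an acetyl group, reports only a limit (the limit of > 30000 nM in this assay, at which 1 of the 2 values shown sits). The step is therefore expected to weaken inhibition beyond the scatter, quite possibly to a limit. Compound 3 is estimated at 20000 nM (range 6000 nM to 60000 nM), an expected step of a 4.2-fold higher number from compound 2 to compound 3 (0.63 log units; beyond the scatter).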

Compound 3, half-maximal inhibitory concentration: 11700 nM
Beside the measured number, compound 3's estimate is 1.7-fold (0.23 log units) above it; the measured number falls inside the stated range.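

Formyl to acetyl on the carbonyl carbon gives a 2.5-fold higher number from compound 2 to compound 3 (0.39 log units; beyond the scatter) in this assay, so this methyl raises the number while leaving a measured value. Methyl in place of hydrogen on an aromatic carbon gives an at least 2.5-fold lower number from compound 1 to compound 3 (0.40 log units; beyond the scatter), which shows that with the acetyl group present this second methyl brings the number down to a measurable value. Compound 1 itself remains a limit: the limit of > 30000 nM in this assay, at which 1 of the 3 values shown sits.

The compounds shown leave open whether the formyl-to-acetyl step would have the same size without the aromatic methyl. They also leave open how a longer chain on the carbonyl carbon, or an amine on the aromatic carbon, would read.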